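The source may report more compounds than this note shows. Statements on the series, on what has been measured and on what is new or still open speak of the compounds shown alone.

Measured so far in a functional assay on the whole organism for inhibition, with Mus musculus as the target, at a dose of 1 mg/kg by the oral route; on this read-out lower numbers stand for less inhibition and higher numbers for more inhibition at the one dose given (going by the name of the read-out): compound 1 `CCN(C(=O)c1c(O)c2c(F)cccc2n(C)c1=O)c1ccccc1` gives 60%; compound 2 `COc1cccc2c1c(O)c(C(=O)N(C)c1ccccc1F)c(=O)n2C` gives 82%; compound 3 `COc1cccc2c1c(O)c(C(=O)N(C)c1c(F)cccc1F)c(=O)n2C` gives 43%.

In this assay compound 3 stands lowest of the three, beyond the scatter below compound 1 and far below compound 2. Compound 4 `COc1cccc2c1c(O)c(C(=O)N(C)c1cc(F)ccc1F)c(=O)n2C` differs from compound 3 by 2,5-difluorophenyl in place of 2,6-difluorophenyl on an amide-type nitrogen. Going by the values given here, no measured pair repeats this exact change. Among the compounds with values here, the one step that bears on it is a number 39 percentage points lower from compound 2 to compound 3 (beyond the scatter), where a fluoro in place of hydrogen cut the read-out sharply. Moving a fluorine within the ring rather than removing it leaves the direction open, but some recovery toward compound 2 seems plausible. The step is estimated at a number 15 percentage points higher from compound 3 to compound 4 (beyond the scatter). Compound 4 is expected to give 58%, within 35% to 80%.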

Compound 4, a percentage reported as inhibition, in the whole organism at one dose (the size of the read-out at that dose, not a potency): 90%
The estimate for compound 4 lay 32 percentage points below the measured number, and the stated range ends below it.
By their numbers in this assay, from the lowest: compound 3; then compound 1; then compounds 2 and 4 (each within the scatter of the next).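

In this assay the place of the second fluorine on the ring carried by the amide-type nitrogen decides the outcome: the same atoms give a number 47 percentage points higher from compound 3 to compound 4 (beyond the scatter) when 2,5-difluorophenyl replaces 2,6-difluorophenyl. Fluoro in place of hydrogen on an aromatic carbon therefore does not lower the number in itself, since it gives a number 8 percentage points higher from compound 2 to compound 4 (within the scatter) in one case and a number 39 percentage points lower from compound 2 to compound 3 (beyond the scatter) in the other. Nothing available explains this difference.

Going by these compounds, it remains open how this position would respond to chloro, methoxy or trifluoromethyl on the phenyl ring, or to a pyridine ring in its place. A single dose also leaves the potency of these compounds undefined.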